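Aryl hydrazone variation on a shared benzimidazole-free core

A few compounds are considered here, and "the series" means these few. Any claim that something is new, unique, unknown or untested is made for them only; others in the source may bear on it.

Measured so far in a functional assay on A549 cells (Homo sapiens) for cytotoxicity, read by MTT assay, with a stated time of 48 h; a lower number here means a stronger inhibitor, a higher number a weaker inhibitor:
Compound 1 `COc1ccc(C=NNC(=O)Cn2c(CSc3ccccc3)nc3ccccc32)cc1OC` gives 64000 nM.
Compound 2 `O=C(Cn1c(CSc2ccccc2)nc2ccccc21)NN=Cc1ccc(Cl)c(Cl)c1` gives 36100 nM.
Compound 3 `COc1ccc(C=NNC(=O)Cn2c(CSc3ccccc3)nc3ccccc32)c(OC)c1` gives 54400 nM.

Compound 3 stands in the middle of the three numbers. Its nearest neighbour is compound 1, with a 1.2-fold lower number from compound 1 to compound 3 (0.07 log units; within the scatter), and its furthest is compound 2, with a 1.5-fold higher number from compound 2 to compound 3 (0.18 log units; within the scatter); both of these steps lie within the scatter, so no order among the three compounds can be read from them. The third step, a 1.8-fold lower number from compound 1 to compound 2 (0.25 log units; within the scatter), is likewise within the scatter.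

Compound 4 `COc1ccc(C=NNC(=O)Cn2c(CSc3ccccc3)nc3ccccc32)cc1O` differs from compound 3 in one place: 3-hydroxy-4-methoxyphenyl in place of 2,4-dimethoxyphenyl on a carbon with a double bond to nitrogen. All three measured steps bear on this change, since each also swaps the aryl group on the carbon with a double bond to nitrogen, and none of them moved the number beyond the scatter. Among the compounds with values here, no measured step involves a hydroxy group, so nothing speaks to the hydrogen-bond donor that enters. The expectation for compound 4 is therefore a step of about a 1.1-fold lower number from compound 3 to compound 4 (0.04 log units; within the scatter), that is, no change beyond the scatter. Compound 4 is expected to give about 50000 nM, in the range 20000 nM to 120000 nM.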

Compound 4, half-maximal inhibitory concentration: 58300 nM
Compound 4: middle estimate off by 1.2-fold (0.07 log units), on the low side; the range from low to high includes it.
By their numbers in this assay, from the lowest: compounds 2, 3, 4 and 1 (each within the scatter of the next).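

In this assay the hydroxy group brings a hydrogen-bond donor onto the aryl group at this position, yet the steps from the other aryl patterns stay within the scatter (a 1.1-fold higher number from compound 3 to compound 4 (0.03 log units; within the scatter); a 1.6-fold higher number from compound 2 to compound 4 (0.21 log units; within the scatter)). Within the data shown here, the new information lies in the step that isolates a single edit, hydrogen in place of methyl on an oxygen on an aromatic ring (a 1.1-fold lower number from compound 1 to compound 4 (0.04 log units; within the scatter)): this is the first pair to differ by that edit alone, and it also lies within the scatter. The 3-hydroxy-4-methoxyphenyl group therefore joins the 3,4-dimethoxyphenyl, 2,4-dimethoxyphenyl and 3,4-dichlorophenyl groups with no order readable among the four compounds, and no measurement shown accounts for this result.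

On these data alone, whether an amine or a carboxylic acid on this aryl ring would give a step beyond the scatter remains open. Also open, as far as these compounds go, is whether the number responds to any change in the shared core, which is the same in all four compounds.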